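Moving a Fluorine on the Amide-Bound Ring

The source may hold more compounds than are shown below. What is called first, only, known or untested is meant among the compounds shown, and "the series" means these compounds.

In a functional assay on HEK293 cells for positive allosteric modulation of metabotropic glutamate receptor 5 (Homo sapiens), read by calcium flux (on this read-out higher numbers stand for larger maximal responses and lower numbers for smaller maximal responses), compound 1 `O=C1c2cc(COc3ccccc3)nn2CCN1c1ccc(F)cc1` gives 79%, and compound 2 `O=C1c2cc(COc3ccccc3)nn2CCN1c1ccc(F)cc1F` gives 101%, the higher of the two numbers. Within the data shown here, the only step measured so far is a number 22 percentage points higher from compound 1 to compound 2 (beyond the scatter). Compound 3 `O=C1c2cc(COc3ccccc3)nn2CCN1c1ccc(F)c(F)c1` differs from compound 2 in that (3,4-difluorophenyl in place of 2,4-difluorophenyl on an amide-type nitrogen in a ring). Among the measured compounds shown here, no measured step rearranges two fluorines in this way, and the step from compound 1 to compound 2 merely adds one fluorine. The expected step of a number 9 percentage points lower from compound 2 to compound 3 (within the scatter) is therefore small and within the usual scatter. Compound 3 is estimated at 92%, with a range from 70% to 112%.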

Compound 3, largest response reached (Emax), in percent of the reference or control that the assay uses: 81%
Compound 3: the middle estimate sits 11 percentage points above what was measured, and the stated range covers the measured number.
By their numbers in this assay, from the lowest: compounds 1 and 3 (each within the scatter of the next); then compound 2.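

So the gain seen earlier does not come simply from adding a second fluorine: moving one fluorine, with the same atoms on the ring, gives a number 20 percentage points lower from compound 2 to compound 3 (beyond the scatter). Added in the 3,4-difluorophenyl arrangement, the same extra fluorine gives only a number 2 percentage points higher from compound 1 to compound 3 (within the scatter), so among these three compounds only the 2,4-difluorophenyl group of compound 2 stands apart. No supporting data explain why the arrangement matters here.

From the compounds shown here alone, whether a chloro or methoxy group on this ring would match compound 2 remains open, as does the response with an unsubstituted phenyl ring.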